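The compounds below may be only part of what the source reports. "The series", "measured", "known", "first", "only" and "open" are said of these compounds alone.

Working notes on the series built on the shared core of compound 1 `CC(C)N1CCN(Cc2csc(N)c2C(=O)c2ccc(Cl)cc2)CC1`, varied only at the group on an amine nitrogen in a ring. In an assay on CHO cells for displacement of a labelled ligand from adenosine receptor A3 (Homo sapiens), read by scintillation counting, with a stated time of 120 min, tested at 10 uM (on this read-out higher numbers stand for more inhibition at the one concentration tested (going by the name of the read-out) and lower numbers for less inhibition), compound 1 gives 0%. Compound 2 `Nc1scc(CN2CCN(c3ccc(Cl)cc3F)CC2)c1C(=O)c1ccc(Cl)cc1` gives 1%, and compound 3 `Nc1scc(CN2CCN(c3ccccc3C(F)(F)F)CC2)c1C(=O)c1ccc(Cl)cc1` gives 0%. Compound 2 stands with the other two inside the scatter of repeated measurements: a number 1 percentage points higher from compound 1 to compound 2 (within the scatter), a number 1 percentage points lower from compound 2 to compound 3 (within the scatter), and likewise no change at the digits printed from compound 1 to compound 3 (within the scatter). No exchange at this nitrogen has so far moved the read-out.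

Compound 4 `Nc1scc(CN2CCN(c3ccc(Cl)c(C(F)(F)F)c3)CC2)c1C(=O)c1ccc(Cl)cc1` has not yet been measured in this assay. Relative to compound 2, (4-chloro-3-(trifluoromethyl)phenyl in place of 4-chloro-2-fluorophenyl on an amine nitrogen in a ring). Going by the values given here, the steps that bear on this change are the two earlier exchanges at the same amine nitrogen in a ring, a number 1 percentage points higher from compound 1 to compound 2 (within the scatter) and a number 1 percentage points lower from compound 2 to compound 3 (within the scatter), both flat. On that basis no step beyond the scatter is expected in either direction in this assay. The expected step is no change at the digits printed from compound 2 to compound 4 (within the scatter). Compound 4 is estimated at 1%, with a range from -6% to 10%.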

Compound 4, a percentage reported as inhibition, at one concentration (the size of the read-out at that concentration, not a potency): 3%
For compound 4 the middle estimate is 2 percentage points below the measured one; measured number inside the range.
By their numbers in this assay, from the lowest: compounds 1, 3, 2 and 4 (each within the scatter of the next).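

In this assay, the 4-chloro-3-(trifluoromethyl)phenyl group on the amine nitrogen in a ring extends the flat picture to a further substituted phenyl group: a number 2 percentage points higher from compound 2 to compound 4 (within the scatter), a number 3 percentage points higher from compound 3 to compound 4 (within the scatter), and a number 3 percentage points higher from compound 1 to compound 4 (within the scatter). The compound 3 to compound 4 pair adds a comparison of two trifluoromethyl-bearing phenyl groups, and that exchange also stays within the scatter, so all four compounds now sit within the scatter of one another at this position. Nothing measured here offers an explanation for this flatness.

Still open, on these data alone, is whether a non-aromatic group on this nitrogen other than isopropyl, such as a longer alkyl chain, a carboxylic acid or a primary amine, would move the read-out beyond the scatter. The compounds shown also leave open whether any change elsewhere on the shared core would do so.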